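This account rests on a few compounds, and the source may have more. Where it says the series, first, only, none or still open, it means among the compounds named here.

Of the compounds shown here, three on a shared core have been tested in a functional assay on HEK293 cells (Homo sapiens) for cytotoxicity (on this read-out lower numbers stand for higher toxicity in this test and higher numbers for lower toxicity in this test), and none of them has yet given a number. Compound 1 `COc1ccc([C@H]2CC(=O)N(c3ccc(C#N)cc3)C2)cc1OC1CCCC1` gives in this assay only the assay limit > 10000 nM. Compound 2 `COc1ccc([C@H]2CC(=O)N(c3ccc(C(F)(F)F)cc3)C2)cc1OC1CCCC1` likewise gives only the limit > 10000 nM. The step that the two limits leave unreadable from compound 1 to compound 2 therefore cannot be read. Compound 3 `COc1ccc([C@H]2CC(=O)N(c3cccc(NC(=O)C(C)=O)c3)C2)cc1OC1CCCC1` also gives only the limit > 10000 nM. Compound 3 thus stands exactly where the whole set stands, at the limit of > 10000 nM in this assay, at which 3 of the 3 values shown sit. Compound 4 `COc1ccc([C@H]2CC(=O)N(c3cccc(NS(=O)(=O)c4cccc(C)c4)c3)C2)cc1OC1CCCC1` differs from compound 3 in one place: (3-methylphenyl)sulfonyl in place of acetylcarbonyl on a nitrogen on an aromatic ring. Within the data shown here, no measured step bears on this change; the only step in the set is unreadable, and every value so far sits at the limit, so there is no measured movement in either direction to build on. The expectation for compound 4 in this assay is therefore no step beyond the scatter, the estimated step being a step that the limit leaves unreadable from compound 3 to compound 4. Compound 4 is expected to give about 15000 nM, between 5000 nM and 50000 nM, most likely reported once more as a limit.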

Compound 4, half-maximal cytotoxic concentration: > 10000 nM
Compound 4 ended at the assay's limit; the forecaster's own chance of this, stated with the estimate: 75%; the middle value does not contradict the limit.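

The change from compound 3 to compound 4 cannot be read in this assay, since both compounds give only a limit: the limit of > 10000 nM in this assay, at which 4 of the 4 values shown sit.

The compounds shown leave open at what concentration any of them would give a measurable number in this assay.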